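Methyl to hydrogen on the pyridin-2-yl group

The source may hold more compounds than are shown below. What is called first, only, known or untested is meant among the compounds shown, and "the series" means these compounds.

Compound 3 `Cc1ccnc(/C(N)=N/NC(=S)N2CCN(c3ccccn3)CC2)c1` has the highest number of the three measured compounds in a functional assay on HeLa cells (Homo sapiens) for cytotoxicity, read by MTT assay, with a stated time of 72 h, tested at 1 uM (a lower number here means less inhibition of growth, a higher number more inhibition of growth at the concentration tested), giving 40.4%; compound 1 `Cc1ccnc(/C(N)=N/NC(=S)N2CCCC2)c1` gives 25.9% and compound 2 `Cc1ccnc(/C(N)=N/NC(=S)N2CCCCC2)c1` gives 15.3%. Among the measured compounds shown here, the only measured step, a number 10.6 percentage points lower from compound 1 to compound 2 (beyond the scatter), concerns the group on the thiocarbonyl carbon and says nothing about the methyl on the aromatic ring. Compound 4 `N/C(=N\NC(=S)N1CCN(c2ccccn2)CC1)c1ccccn1` differs from compound 3 by hydrogen in place of methyl on an aromatic carbon, read one bond further out as 4-methylpyridin-2-yl to pyridin-2-yl. For the measured compounds named here, no measured pair bears on this change, so no step beyond the scatter is expected; the estimate for compound 4 is 37% with a range of 24% to 50%. The step expected, a number 3.4 percentage points lower from compound 3 to compound 4 (within the scatter), is therefore small and uncertain in direction.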

Compound 4, percent growth inhibition at one concentration: 16.7%
The estimate for compound 4 lay 20.3 percentage points above the measured number, outside the stated range (below it).
By their numbers in this assay, from the lowest: compounds 2, 4 and 1 (each within the scatter of the next, the first and the last beyond it); then compound 3.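

In this assay, the methyl on the aromatic carbon opposite the ring nitrogen proves to matter: hydrogen in its place gives a number 23.7 percentage points lower from compound 3 to compound 4 (beyond the scatter). The position therefore affects growth inhibition at the concentration tested, at least with the group on the thiocarbonyl carbon shared by this pair. No available evidence bears on the reason for this step. As far as these compounds go, whether the change has a similar size with pyrrolidin-1-yl or piperidin-1-yl on the thiocarbonyl carbon remains open. Also open, from the compounds shown here alone, is what an ethyl, a methoxy or a chlorine on that aromatic carbon would give.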